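The compounds below may be only part of what the source reports. "The series", "measured", "known", "first", "only" and "open" are said of these compounds alone.

Compound 1 `CCOC(=O)/C=C/c1ccc(OC(=O)c2nc(C)c(C)nc2C)c(O)c1`: 375%
Compound 2 `Cc1nc(C)c(C(=O)Oc2cccc(/C=C/C(=O)O)c2)nc1C`: 103%
Compound 3 `Cc1nc(C)c(C(=O)Oc2ccc(/C=C/C(=O)O)cc2O)nc1C`: 601%

Of the compounds shown here, three have been measured in a functional assay on EA.hy 926 cells (Homo sapiens) for cytotoxicity, read by MTT assay, with stated times of 24 h and 12 h, tested at 100 uM; a lower number here means a weaker effect, a higher number a stronger effect of the compound at the concentration tested. Compound 3 gives 601%, and compound 1, which carries the change (ethyl in place of hydrogen on an oxygen next to a carbonyl group), gives 375%. The step of a number 226 percentage points lower from compound 3 to compound 1 (beyond the scatter) is large and lies well beyond the scatter. Compound 2 gives 103% and stands lowest of the three, with its steps to compound 1 and to compound 3 both beyond the scatter. The difference between the core of compound 2 and the core of compound 3 is not broken down here.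

Compound 4 `CCOC(=O)/C=C/c1cccc(OC(=O)c2nc(C)c(C)nc2C)c1` has not yet been measured. Among the compounds with values here, it differs from compound 2 by ethyl in place of hydrogen on an oxygen next to a carbonyl group, which is the same change as the one from compound 3 to compound 1, made at the same place. Within the data shown here, the one measured example of this change lowered the read-out sharply, so a decrease is expected from compound 2 to compound 4 as well, although compound 2 already stands low, and the expected step is a number 28 percentage points lower from compound 2 to compound 4 (beyond the scatter). Among the measured compounds shown here, this expectation rests on the single step of a number 226 percentage points lower from compound 3 to compound 1 (beyond the scatter) in a different core, so it carries wide uncertainty. Compound 4 is therefore estimated at 75% in this assay, with a range from 35% to 140%.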

Compound 4, a percentage reported as activity, at one concentration (the size of the read-out at that concentration, not a potency): 47%
For compound 4 the middle estimate is 28 percentage points above the measured one; the range from low to high includes it.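

In this assay, putting ethyl in place of hydrogen on an oxygen next to a carbonyl group lowers the read-out on a second core (a number 56 percentage points lower from compound 2 to compound 4 (beyond the scatter)), so the direction of the change carries over between the two pairs shown. The size of the step does not carry over, and the two steps stand clearly apart: (the same change on two cores in this assay, a number 226 percentage points lower (beyond the scatter) from compound 3 to compound 1 and a number 56 percentage points lower (beyond the scatter) from compound 2 to compound 4, 170 percentage points apart, beyond the scatter of two such steps). Two pairs do not show why the size differs, nor can they show whether the same direction would hold on a further core, and a fall on one core gives no reliable measure of the fall on another.

The compounds shown leave open whether a methyl group or a longer chain on that oxygen, or an amide in place of the ester, would lower the read-out in the same way. Within the data shown here, they also leave open which part of the two cores goes with the larger step, as no pair among them links the two cores through a difference in one place.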